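The source may report more compounds than this note shows. Statements on the series, on what has been measured and on what is new or still open speak of the compounds shown alone.

Measured in a functional assay on OVCAR-3 cells (Homo sapiens) for antiproliferative activity, read by MTT assay, with a stated time of 24 h; a lower number here means a stronger inhibitor, a higher number a weaker inhibitor:
- compound 1 `Cc1cccc(NNC(=O)c2cccc(NS(=O)(=O)c3cnc(O)nc3O)c2)c1`: > 20000 nM
- compound 2 `O=C(NNC(=O)c1cccc(NS(=O)(=O)c2cnc(O)nc2O)c1)c1cccc(Cl)c1`: 13500 nM

The entry for compound 1, > 20000 nM, is a limit of the assay and not a number. Among the measured compounds shown here, compound 2 therefore holds the only true number in this assay, at 13500 nM. Compound 3 `O=C(NNC(=O)c1ccccc1F)c1cccc(NS(=O)(=O)c2cnc(O)nc2O)c1` keeps the shared core of compound 2 and carries 2-fluorophenyl in place of 3-chlorophenyl on a carbonyl carbon. For the measured compounds named here, only one measured step touches this end of the molecule, an at least 1.4-fold lower number from compound 1 to compound 2 (0.17 log units; that floor lies within the scatter). That step exchanges a different pair of groups, and its size is known only as a floor, so it offers little guidance. No step beyond the scatter is therefore expected in this assay, and no direction can be assigned. The expected change is a 1.0-fold higher number from compound 2 to compound 3 (0.02 log units; within the scatter). For compound 3 the estimated value is 14000 nM, with an expected range of 6000 nM to 30000 nM.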

Compound 3, half-maximal inhibitory concentration: 10800 nM
Beside the measured number, compound 3's estimate is 1.3-fold (0.11 log units) above it; the measured number falls inside the stated range.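

In this assay, 2-fluorophenyl in place of 3-chlorophenyl on a carbonyl carbon gives a 1.3-fold lower number from compound 2 to compound 3 (0.10 log units; within the scatter). Among the compounds shown here, this is the first step at this position read between two true numbers, and it does not separate the two groups. The other new step, an at least 1.8-fold lower number from compound 1 to compound 3 (0.26 log units; that floor lies within the scatter), gives only a floor, and compound 1 remains a limit of the assay: the limit of > 20000 nM in this assay, at which 1 of the 3 values shown sits.

Going by these compounds, what stays open is whether this position responds to any change at all, since the two groups compared here are both phenyl rings carrying a single halogen. Plain phenyl, or an amine, a carboxylic acid or a longer chain on this carbonyl carbon, could still move the number beyond the scatter or leave it where it is.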